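A few compounds are considered here, and "the series" means these few. Any claim that something is new, unique, unknown or untested is made for them only; others in the source may bear on it.

Compound 1 `CC1CCN(c2nc(Cl)nc3c2ncn3Cc2ccc(/C=C/C(=O)Nc3ccccc3N)cc2)CC1` — 10.8%
Compound 2 `Nc1ccccc1NC(=O)/C=C/c1ccc(Cn2cnc3c(Nc4cccc(Cl)c4)nc(Cl)nc32)cc1` — 29.4%

In a functional assay on NCI-H460 cells (Homo sapiens) for antiproliferative activity, read by CCK-8 assay, with a stated time of 72 h, tested at 8 uM (a lower number here means a weaker effect, a higher number a stronger effect of the compound at the concentration tested), compound 1 gives 10.8% and compound 2 gives 29.4%, so compound 2 stands higher of the two measured compounds. For the measured compounds named here, the single measured step, a number 18.6 percentage points higher from compound 1 to compound 2 (beyond the scatter), changes the group on the shared core and does not touch the aryl ring that differs here.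

Compound 3 `Nc1ccccc1NC(=O)/C=C/c1ccc(Cn2cnc3c(Nc4cccc(OC(F)(F)F)c4)nc(Cl)nc32)cc1` differs from compound 2 in one place: trifluoromethoxy in place of chloro on an aromatic carbon. Going by the values given here, no measured step bears on this exchange. Without a comparison in this assay, the expectation for compound 3 is a step of about a number 0.6 percentage points higher from compound 2 to compound 3 (within the scatter), that is, no change beyond the scatter in either direction. Compound 3 is therefore estimated at 30% in this assay, expected to fall between 15% and 48%.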

Compound 3, a percentage reported as inhibition, at one concentration (the size of the read-out at that concentration, not a potency): 66.7%
Beside the measured number, compound 3's estimate is 36.7 percentage points below it; measured number above the stated range.
By their numbers in this assay, from the lowest: compound 1; then compound 2; then compound 3.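

In this assay, the substituent on the aryl ring of the amino group proves to matter: trifluoromethoxy in place of chloro, on an aromatic carbon meta to a large group, gives a number 37.3 percentage points higher from compound 2 to compound 3 (beyond the scatter) on the same core. Measured against the 4-methylpiperidin-1-yl group, the (3-(trifluoromethoxy)phenyl)amino group gives a number 55.9 percentage points higher from compound 1 to compound 3 (beyond the scatter), so the size of the gain over that group depends on what the aryl ring carries. Nothing given here explains why this exchange raises the inhibition.

The compounds shown leave open how a methoxy, a trifluoromethyl or a nitrile group would read at this place, and whether trifluoromethoxy would keep its effect on another carbon of the ring. They also leave open what an amine would do in place of the chloro that remains on the shared core.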